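The source may report more compounds than this note shows. Statements on the series, on what has been measured and on what is new or still open speak of the compounds shown alone.

Measured in a functional assay on A549 cells (Homo sapiens) for inhibition, read by sulforhodamine B assay, with a stated time of 48 h, tested at 50 uM; a lower number here means less inhibition of growth, a higher number more inhibition of growth at the concentration tested:
- compound 1 `CCCOc1ccc([C@@H]2CC(=O)c3cc(CC=C(C)C)c(OC)cc3O2)cc1`: 43%
- compound 2 `COc1cc2c(cc1CC=C(C)C)C(=O)C[C@@H](c1ccc(Oc3cccc([N+](=O)[O-])c3)cc1)O2`: 37%
- compound 3 `COc1ccc([C@@H]2C/C(=N/OCc3cn(-c4ccccc4CO)nn3)c3cc(CC=C(C)C)c(OC)cc3O2)cc1`: 100%

Compound 2 has the lowest of the three numbers in this assay, although its value lies within the scatter of compound 1. Compound 3, at 100%, lies well beyond the scatter of compound 2.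

The next compound is compound 4 `C#CCOc1ccc([C@@H]2CC(=O)c3cc(CC=C(C)C)c(OC)cc3O2)cc1`, which has propargyl in place of 3-nitrophenyl on an oxygen on an aromatic ring.

Among the measured compounds shown here, only one measured step bears on this change: a number 6 percentage points lower from compound 1 to compound 2 (within the scatter). It exchanges propyl and 3-nitrophenyl at the same place and stays within the scatter. Compound 3 differs from the others in more than one place, so it offers no guide here. For the measured compounds named here, no measured step involves propargyl itself, so the expectation remains loose.

Judging by that single step, no shift beyond the scatter is expected in this assay. The expected step, a number 5 percentage points higher from compound 2 to compound 4 (within the scatter), is small. For compound 4 the estimated value is 42%, with an expected range from 29% to 55%.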

Compound 4, percent growth inhibition at one concentration: 53%
Compound 4: the middle estimate sits 11 percentage points below what was measured; low and high end bracket the measured number.
By their numbers in this assay, from the lowest: compounds 2, 1 and 4 (each within the scatter of the next, the first and the last beyond it); then compound 3.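

Among the compounds shown here, at the oxygen on an aromatic ring, propargyl in place of 3-nitrophenyl gives a number 16 percentage points higher from compound 2 to compound 4 (beyond the scatter) in this assay, the first step at this place to clear the scatter, though it remains modest. The closer comparison, ethynyl in place of ethyl on a saturated chain carbon bound to that oxygen, gives a number 10 percentage points higher from compound 1 to compound 4 (within the scatter) and so shows no separate contribution from the triple bond. Nothing available accounts for the step from 3-nitrophenyl to propargyl.

Open, as far as these compounds go, is how a longer chain, a benzyl group or a chain bearing an amine on this oxygen would read in this assay. Compound 3, at 100%, differs from the other compounds in more than one place, so its value says nothing about the group on this oxygen.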